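Phenyl in place of methoxy: notes on compound 4

The compounds below may be only part of what the source reports. "The series", "measured", "known", "first", "only" and "open" are said of these compounds alone.

In a functional assay on the whole organism for inhibition, with Rattus norvegicus as the target (a lower number here means that less compound is needed, a higher number that more compound is needed for the effect), compound 1 `CC(C)c1ccc(OC(C)(Cc2ccccc2)C(=O)O)cc1` gives > 10 mg/kg, which is a limit of the assay. Going by the values given here, compound 2 `CCc1ccccc1CC(C)(Oc1ccc(C(C)C)cc1)C(=O)O` gives 5 mg/kg, the only true number so far. Compound 3 `COc1ccccc1CC(C)(Oc1ccc(C(C)C)cc1)C(=O)O` stands at > 10 mg/kg, again a limit of the assay and not a number. Compound 3 therefore sits at the limit of > 10 mg/kg in this assay, at which 2 of the 3 values shown sit.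

The next structure is compound 4 `CC(C)c1ccc(OC(C)(Cc2ccccc2-c2ccccc2)C(=O)O)cc1`, with phenyl in place of methoxy on an aromatic carbon, ortho to a large group: phenyl in place of methoxy on an aromatic carbon.

Among the compounds with values here, three measured steps bear on this change. Ethyl in place of hydrogen gives an at least 2.0-fold lower number from compound 1 to compound 2 (0.30 log units; that floor lies within the scatter). Methoxy in place of ethyl gives an at least 2.0-fold higher number from compound 2 to compound 3 (0.30 log units; that floor lies within the scatter). Methoxy in place of hydrogen gives a step that the two limits leave unreadable from compound 1 to compound 3. Within the data shown here, no measured step tests phenyl itself, so the expectation is loose. It leans on compound 2 at 5 mg/kg, which also carries a group without oxygen where compound 3 has methoxy. A move towards a lower number is expected, of modest and uncertain size, and another limit remains possible. The expected step in this assay is an at least 1.6-fold lower number from compound 3 to compound 4 (0.22 log units; that floor lies within the scatter). Compound 4 is estimated at 6 mg/kg, with an expected range from 1.5 mg/kg to 25 mg/kg.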

Compound 4, dose for half-maximal effect: 10 mg/kg
Estimate against measurement, compound 4: 1.7-fold (0.22 log units) below; low and high end bracket the measured number.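

In this assay compound 4 gives 10 mg/kg, a true number and not a limit of the assay, so an entering group of six heavy atoms with a six-membered aromatic ring still yields a readable result on this aromatic carbon, ortho to a large group. Phenyl in place of methoxy gives a number no higher from compound 3 to compound 4 (the limit leaves the size open), and phenyl in place of hydrogen gives a number no higher from compound 1 to compound 4 (the limit leaves the size open). Phenyl in place of ethyl gives a 2.0-fold higher number from compound 2 to compound 4 (0.30 log units; within the scatter), so the two groups are not told apart at this position, and ethyl no longer stands alone as the only group here with a true number. Compound 1 and compound 3 each remain a limit of the assay, and the size of the steps from them to compound 4 cannot be read: the limit of > 10 mg/kg in this assay, at which 2 of the 4 values shown sit.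

How far hydrogen and methoxy lie from phenyl at this position therefore stays unknown, and no order among these groups can be given. Also open, from the compounds shown here alone, is whether an amine, a longer chain such as propyl, or a phenyl carrying a chloro group would give a true number on this aromatic carbon, and whether ethyl or phenyl would do so elsewhere on the same ring.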